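Capping the terminal amine of compound 3

The source may report more compounds than this note shows. Statements on the series, on what has been measured and on what is new or still open speak of the compounds shown alone.

In a functional assay on K562 cells (Homo sapiens) for inhibition, read by MTT assay, with a stated time of 72 h (a higher number here means a weaker inhibitor, a lower number a stronger inhibitor), three compounds sharing one core have been measured. Compound 1 (`Cc1ccc(-c2nnc(-c3ccc(C)c(C(F)(F)F)c3)o2)cc1Nc1nccc(-c2cccnc2)n1`) gives > 30000 nM, which is a limit of the assay and not a number. Compound 2 (`Cc1ccc(-c2nnc(-c3ccc(F)c(C(F)(F)F)c3)o2)cc1Nc1nccc(-c2cccnc2)n1`) gives 29700 nM. Compound 3 (`Cc1ccc(-c2nnc(-c3ccc(CN4CCN(CCN)CC4)c(C(F)(F)F)c3)o2)cc1Nc1nccc(-c2cccnc2)n1`) gives 300 nM, the lowest number shown, which makes it the strongest inhibitor of the three.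

Two large steps bear on what comes next, an at least 100-fold lower number from compound 1 to compound 3 (2.00 log units; beyond the scatter) and a 99-fold lower number from compound 2 to compound 3 (2.00 log units; beyond the scatter). Both introduced the 4-(2-aminoethyl)piperazin-1-yl group as a whole. Compound 4 (`C=CC(=O)NCCN1CCN(Cc2ccc(-c3nnc(-c4ccc(C)c(Nc5nccc(-c6cccnc6)n5)c4)o3)cc2C(F)(F)F)CC1`) keeps that group and alters only its end, with vinylcarbonyl in place of hydrogen on an amine nitrogen. Among the compounds with values here, no measured compound carries this vinylcarbonyl, so the expectation is uncertain. Most of the gain seen in a 99-fold lower number from compound 2 to compound 3 (2.00 log units; beyond the scatter) is expected to survive, with a modest rise in the number in this assay. The expected change is a 2.0-fold higher number from compound 3 to compound 4 (0.30 log units; within the scatter). The estimate for compound 4 is 600 nM, with an expected range of 120 nM to 3000 nM.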

Compound 4, half-maximal inhibitory concentration: 600 nM
Estimate against measurement, compound 4: no gap at the digits printed; the measured number falls inside the stated range.
By their numbers in this assay, from the lowest: compounds 3 and 4 (each within the scatter of the next); then compound 2. At a limit, above all of these: compound 1.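

In this assay, placing vinylcarbonyl on the terminal amine nitrogen gives a 2.0-fold higher number from compound 3 to compound 4 (0.30 log units; within the scatter), so compound 3 and compound 4 cannot be told apart in this test. The earlier compounds shown here showed only what the 4-(2-aminoethyl)piperazin-1-yl group does as a whole, whereas this pair shows that its free amino end is not needed to keep the number at this level: the 2-((vinylcarbonyl)amino)ethyl chain serves as well. Nothing shown here explains this result.

Going by these compounds, whether the double bond of the vinylcarbonyl contributes anything remains open, and a saturated acetyl group on the same nitrogen would be the direct comparison. Also open, on these data alone, is how a methyl group on this amine, or a longer chain between it and the piperazine, would read.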